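The source may report more compounds than this note shows. Statements on the series, on what has been measured and on what is new or still open speak of the compounds shown alone.

Measured in a physicochemical assay for lipophilicity, at pH 7.4; a higher number here means a more lipophilic compound, a lower number a more polar compound:

- compound 1 `CCc1ccc(N(CC(C)C)S(=O)(=O)c2ccc3c(c2)C(O)CC(C2CCOCC2)O3)cc1`: 4.12
- compound 2 `CC(C)CN(c1ccccc1F)S(=O)(=O)c1ccc2c(c1)C(O)CC(C1CCOCC1)O2`: 3.39
- compound 3 `CC(C)CN(c1ccc(C#N)cc1)S(=O)(=O)c1ccc2c(c1)C(O)CC(C1CCOCC1)O2`: 3.07

Compound 3 has the lowest number of the three in this assay. Compound 4 `CC(C)CN(c1cc2ccccc2s1)S(=O)(=O)c1ccc2c(c1)C(O)CC(C1CCOCC1)O2` has 1-benzothiophen-2-yl in place of 4-cyanophenyl on a sulfonamide nitrogen. Going by the values given here, none of the measured compounds carries 1-benzothiophen-2-yl, so no measured step covers this change directly. The nearest guides are the two steps that end at 4-cyanophenyl: the modest a number 0.32 log units lower from compound 2 to compound 3 (beyond the scatter) and the large a number 1.05 log units lower from compound 1 to compound 3 (beyond the scatter). Both lead downward, so replacing 4-cyanophenyl gave a higher number in each measured comparison when they are read in reverse. On these data alone, how far the number rises with 1-benzothiophen-2-yl remains open. A large upward step in this assay is therefore expected, close in size to the larger of those two, and the estimate is a number 1.03 log units higher from compound 3 to compound 4 (beyond the scatter). For compound 4 the estimated value is 4.1, with an expected range from 3.6 to 4.6.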

Compound 4, distribution coefficient: 3.92
Compound 4: middle estimate off by 0.18 log units, on the high side; measured number inside the range.
By their numbers in this assay, from the lowest: compound 3; then compound 2; then compounds 4 and 1 (each within the scatter of the next).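

Going by these compounds alone, on a sulfonamide nitrogen, 1-benzothiophen-2-yl, the first group here with a five-membered aromatic ring and a sulfur atom, sits clearly apart from two of the earlier groups in this assay: replacing 4-cyanophenyl gives a number 0.85 log units higher from compound 3 to compound 4 (beyond the scatter), and replacing 2-fluorophenyl gives a number 0.53 log units higher from compound 2 to compound 4 (beyond the scatter). Against 4-ethylphenyl the same position shows no readable difference, with a number 0.20 log units lower from compound 1 to compound 4 (within the scatter), so two groups of quite different ring make-up cannot be told apart in this assay. Nothing in the data shown explains these steps.

The compounds shown leave open whether the step belongs to the sulfur or to the ring system as a whole, which 1-benzofuran-2-yl or plain phenyl on the same nitrogen would help to separate. Also open, on these data alone, is where the number would lie with an amine or a carboxylic acid on the aromatic ring.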